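Trifluoromethyl-substituted chloroquinoline stilbenes in an antiproliferative assay

The source may report more compounds than this note shows. Statements on the series, on what has been measured and on what is new or still open speak of the compounds shown alone.

Measured compounds:
compound 1, `FC(F)(F)c1ccc(/C=C\c2cc3ccccc3nc2Cl)cc1`, 4260 nM
compound 2, `COc1ccc2nc(Cl)c(/C=C\c3cccc(C(F)(F)F)c3)cc2c1`, 2780 nM
compound 3, `COc1ccc2nc(Cl)c(/C=C\c3cc(C(F)(F)F)cc(C(F)(F)F)c3)cc2c1`, 4700 nM

Three compounds were tested in a functional assay on MCF7 cells (Homo sapiens) for antiproliferative activity, read by sulforhodamine B assay, with a stated time of 72 h; on this read-out higher numbers stand for weaker inhibition and lower numbers for stronger inhibition. In this assay compound 1 gives 4260 nM, compound 2 gives 2780 nM and compound 3 gives 4700 nM; all three numbers lie within the scatter of one another. The difference between the core of compound 1 and the core of compound 2 is not broken down here.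

Compound 3 differs from compound 2 by trifluoromethyl in place of hydrogen on an aromatic carbon, and this step, a 1.7-fold higher number from compound 2 to compound 3 (0.23 log units; within the scatter), stays within the scatter. Compound 4, `FC(F)(F)c1ccc(/C=C\c2cc3ccccc3nc2Cl)c(C(F)(F)F)c1`, has not been measured. It differs from compound 1 by trifluoromethyl in place of hydrogen on an aromatic carbon. This is the same kind of change as that from compound 2 to compound 3, but not the same: in compound 4 the trifluoromethyl group sits ortho to a large group, whereas in compound 3 it sits meta to a large group. A step of similar size in this assay is expected, resting on compound 3, whose step is a 1.7-fold higher number from compound 2 to compound 3 (0.23 log units; within the scatter); the expected step is a 1.5-fold higher number from compound 1 to compound 4 (0.18 log units; within the scatter). Compound 4 is estimated at 6500 nM, between 2500 nM and 17000 nM.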

Compound 4, half-maximal inhibitory concentration: 10500 nM
Beside the measured number, compound 4's estimate is 1.6-fold (0.21 log units) below it; low and high end bracket the measured number.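

In this assay, trifluoromethyl in place of hydrogen on an aromatic carbon gives a 2.5-fold higher number from compound 1 to compound 4 (0.39 log units; beyond the scatter), a modest move towards weaker inhibition on the core of compound 1. Set beside the same change on the core of compound 2, the two steps point the same way and cannot be told apart: the same change on two cores in this assay, a 1.7-fold higher number (0.23 log units; within the scatter) from compound 2 to compound 3 and a 2.5-fold higher number (0.39 log units; beyond the scatter) from compound 1 to compound 4, 1.5-fold (0.16 log units) apart, within the scatter of two such steps This suggests that the change carries over between these two cores without a detectable difference in size, but it rests on only two pairs, one of whose steps stays within the scatter, and it does not show that the entering group's place is irrelevant, since in compound 4 that group sits ortho to a large group.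

The compounds shown leave open whether an amine or a carboxylic acid on that same aromatic carbon would shift the number in the same direction as trifluoromethyl. They also leave open whether a methyl group there would give a step of similar size on either core.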